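Compound 3: 3-hydroxypropyl in place of 3-(dimethylamino)propyl

The compounds below may be only part of what the source reports. "The series", "measured", "known", "first", "only" and "open" are said of these compounds alone.

In a functional assay on K562 cells (Homo sapiens) for antiproliferative activity, read by MTT assay, with a stated time of 48 h (a lower number here means a stronger inhibitor, a higher number a weaker inhibitor), compound 1 `CN(C)CCCn1nc(C2=C(c3cn(C)c4ccccc34)C(=O)N(c3ccccc3)C2=O)c2cccnc21` gives 1700 nM, and compound 2 `CN(C)CCCn1nc(C2=C(c3cn(C)c4ccccc34)C(=O)NC2=O)c2cccnc21` gives 50400 nM, the higher of the two numbers. Among the measured compounds shown here, the only measured step, a 30-fold higher number from compound 1 to compound 2 (1.47 log units; beyond the scatter), is hydrogen in place of phenyl on an amide-type nitrogen in a ring. It lies at another place and does not test the chain. Compound 3 `Cn1cc(C2=C(c3nn(CCCO)c4ncccc34)C(=O)NC2=O)c2ccccc21` carries hydroxy in place of dimethylamino on a saturated chain carbon, three bonds along the chain from an aromatic nitrogen. For the measured compounds named here, no measured step covers this change, so none beyond the scatter is expected in this assay, with a slight lean towards a higher number. The expected change is a 1.4-fold higher number from compound 2 to compound 3 (0.14 log units; within the scatter). The estimate for compound 3 is 70000 nM, with a range of 20000 nM to 200000 nM.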

Compound 3, half-maximal inhibitory concentration: 85800 nM
Estimate against measurement, compound 3: 1.2-fold (0.09 log units) below; low and high end bracket the measured number.
By their numbers in this assay, from the lowest: compound 1; then compounds 2 and 3 (each within the scatter of the next).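

In this assay, among the compounds shown here, the first change on the chain, 3-hydroxypropyl in place of 3-(dimethylamino)propyl, gives a 1.7-fold higher number from compound 2 to compound 3 (0.23 log units; within the scatter) and so does not separate the two compounds. On the core with the amide hydrogen, the chain end can therefore carry either dimethylamino or hydroxy without a change beyond the scatter. No supporting measurement bears on this result. On these data alone, whether the same holds with phenyl on the amide-type nitrogen, as in compound 1, stays open. So does the effect of a carboxylic acid at the chain end or a longer chain.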